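The compounds below may be only part of what the source reports. "The series", "measured", "known", "first", "only" and "open" are said of these compounds alone.

Measured in a functional assay on MCF7 cells (Homo sapiens) for antiproliferative activity, read by CCK-8 assay, with a stated time of 72 h; a higher number here means a weaker inhibitor of growth, a lower number a stronger inhibitor of growth:
- compound 1 `CCCNC(=O)c1ccc2c(ccn2-c2ncc3c(n2)N(c2ccn(C)n2)C(CC)C(=O)N3C)c1`: 6420 nM
- compound 2 `CC[C@@H]1C(=O)N(C)c2cnc(-n3ccc4cc(C(=O)NC(C)C)ccc43)nc2N1C1CCCC1`: 1670 nM

Compound 1 at 6420 nM holds the higher of the two numbers in this assay, so it is the weaker inhibitor of growth of the pair. Compound 2 at 1670 nM lies lower, by more than the usual scatter.

Going by the values given here, compound 3 `CCC1C(=O)N(C)c2cnc(-n3ccc4cc(C(=O)NC5CCCC5)ccc43)nc2N1c1ccn(C)n1` has no measurement yet. Compared with compound 1, it carries cyclopentyl in place of propyl on an amide-type nitrogen. Among the compounds with values here, no measured pair differs in one place only, so the data give no direct size for this change and the expectation stays loose. Within the data shown here, with compound 1 at 6420 nM, the higher of only two numbers, a small shift towards a lower number is the working guess. The expected change in this assay is a 1.8-fold lower number from compound 1 to compound 3 (0.26 log units; within the scatter), a step within the scatter. For compound 3 the estimated value is 3500 nM, with an expected range from 1000 nM to 10000 nM.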

Compound 3, concentration for 50% growth inhibition: "not active" (no number reported)
Nothing numeric was reported for compound 3; the estimate stays without a comparison.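

In this assay, going by these compounds alone, compound 3 is reported as not active, with no number, so no step from compound 1 to compound 3 can be read. No evidence at hand bears on this result. The compounds shown leave open how far cyclopentyl in place of propyl on an amide-type nitrogen shifts growth inhibition.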